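A few compounds are considered here, and "the series" means these few. Any claim that something is new, unique, unknown or untested is made for them only; others in the source may bear on it.

Compound 1 `CC(C)n1ncc2c(C(=O)NCc3cn(-c4ccccc4)nn3)cccc21` gives in a functional assay on MCF7 cells (Homo sapiens) for inhibition, read by MTT assay, with a stated time of 72 h (on this read-out higher numbers stand for weaker inhibition and lower numbers for stronger inhibition), only a limit, > 40000 nM. Compound 2 `CC(C)n1ncc2c(C(=O)NCc3cn(-c4ccc(I)cc4)nn3)cccc21` gives in this assay only a limit, > 40000 nM. Compound 3 `COc1ccc(-n2cc(CNC(=O)c3cccc4c3cnn4C(C)C)nn2)cc1` gives in this assay only a limit, > 40000 nM.

Compound 2 thus stands at the limit of this assay, as do both other measured compounds, which is all that the limit of > 40000 nM in this assay, at which 3 of the 3 values shown sit, records. The steps a step that the two limits leave unreadable from compound 1 to compound 2, a step that the two limits leave unreadable from compound 1 to compound 3 and a step that the two limits leave unreadable from compound 2 to compound 3 are each left unreadable by the two limits, so no change on an aromatic carbon has yet shown a readable size. Compound 4 `COc1ccc(Cn2cc(CNC(=O)c3cccc4c3cnn4C(C)C)nn2)cc1` differs from compound 2 by 4-methoxybenzyl in place of 4-iodophenyl on an aromatic nitrogen. Going by the values given here, no measured step bears on this change in a readable way, and the three measured compounds give no direction, so a step of no readable size is expected. Compound 4 is therefore estimated at 40000 nM, within 15000 nM to 100000 nM, with the step of a number no higher from compound 2 to compound 4 (the limit leaves the size open) expected to stay within the scatter.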

Compound 4, half-maximal inhibitory concentration: > 40000 nM
Compound 4 gave a limit, no number; the forecaster's own chance of this, stated with the estimate: 80%; the middle value sits exactly at the limit.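

In this assay, going by these compounds alone, compound 4 gives only a limit, > 40000 nM, so no step from compound 1, compound 2 or compound 3 to compound 4 can be read. The compounds shown leave open whether any of these changes alters inhibition: the limit of > 40000 nM in this assay, at which 4 of the 4 values shown sit.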